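From Fluorophenyl to Hydroxyphenyl on the Shared Core

The compounds below may be only part of what the source reports. "The series", "measured", "known", "first", "only" and "open" are said of these compounds alone.

Values measured in a functional assay on MCF7 cells (Homo sapiens) for antiproliferative activity, read by MTT assay, with a stated time of 48 h (on this read-out higher numbers stand for weaker inhibition and lower numbers for stronger inhibition), so far:
compound 1 `CC(=O)N1N=C(c2ccc3ccccc3c2)OC1c1cccc(Br)c1` gives 2.34 ug/mL
compound 2 `CC(=O)N1N=C(c2ccc3ccccc3c2)OC1c1ccccc1F` gives 3.44 ug/mL
compound 3 `CC(=O)N1N=C(c2ccc3ccccc3c2)OC1c1ccc(F)cc1` gives 3.02 ug/mL

Compound 3, at 3.02 ug/mL, cannot be separated from the other two compounds, since the steps leading to it are small: a 1.3-fold higher number from compound 1 to compound 3 (0.11 log units; within the scatter) and a 1.1-fold lower number from compound 2 to compound 3 (0.06 log units; within the scatter). The remaining step, a 1.5-fold higher number from compound 1 to compound 2 (0.17 log units; within the scatter), is just as modest. The next compound, compound 4 `CC(=O)N1N=C(c2ccc3ccccc3c2)OC1c1ccccc1O`, has 2-hydroxyphenyl in place of 4-fluorophenyl on a saturated ring carbon. Going by the values given here, all three measured steps exchange one halogen-bearing phenyl group for another, and no measured compound carries a 2-hydroxyphenyl, so they offer only indirect guidance. Even so, with compound 2 and compound 3 showing a 1.1-fold lower number from compound 2 to compound 3 (0.06 log units; within the scatter), a change beyond the scatter in this assay is not expected, and no direction is favoured. The estimate amounts to a 1.1-fold higher number from compound 3 to compound 4 (0.03 log units; within the scatter), which is expected to be too small to read as a real change. Compound 4 is estimated at 3.2 ug/mL, with an expected range from 1.4 ug/mL to 7.5 ug/mL.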

Compound 4, half-maximal inhibitory concentration: 2.12 ug/mL
The estimate for compound 4 lay 1.5-fold (0.18 log units) above the measured number; the range from low to high includes it.
By their numbers in this assay, from the lowest: compounds 4, 1, 3 and 2 (each within the scatter of the next).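

In this assay, going by these compounds alone, 2-hydroxyphenyl is the first group on this saturated ring carbon to bring a hydrogen-bond donor and acceptor, yet the numbers stay within the scatter of those for the halogen-bearing phenyl groups (a 1.4-fold lower number from compound 3 to compound 4 (0.15 log units; within the scatter); a 1.1-fold lower number from compound 1 to compound 4 (0.04 log units; within the scatter)). Even the direct exchange of hydroxy in place of fluoro on an aromatic carbon, the largest of these steps (a 1.6-fold lower number from compound 2 to compound 4 (0.21 log units; within the scatter)), cannot be read as a real change, so this position has so far shown no measurable response to this change of group. Nothing available explains why these numbers lie so close together.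

Still open, from the compounds shown here alone, is whether a phenyl group carrying an amine, a carboxylic acid or a methoxy group at this position would give a number beyond the scatter. The compounds shown also cannot say whether the shared core responds to changes anywhere else.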